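Hydroxy added to the acetylphenyl end of the series

This account rests on a few compounds, and the source may have more. Where it says the series, first, only, none or still open, it means among the compounds named here.

Measured in a functional assay on ileum (Cavia porcellus) for antagonist activity, with a stated time of 30 s; a higher number here means a weaker inhibitor, a lower number a stronger inhibitor:
compound 1 `O=C(O)c1cc(=O)c2ccc(OCCCCCOc3ccccc3)cc2o1`: 0.4 ug/mL
compound 2 `CC(=O)c1ccc(OCCCCCOc2ccc3c(=O)cc(C(=O)O)oc3c2)cc1`: 3.5 ug/mL

Of these two compounds, compound 2 has the higher number, 3.5 ug/mL, and so is the weaker inhibitor. The next structure is compound 3 `CC(=O)c1ccc(OCCCCCOc2ccc3c(=O)cc(C(=O)O)oc3c2)cc1O`, which has hydroxy in place of hydrogen on an aromatic carbon, ortho to the acetyl group: hydroxy in place of hydrogen on an aromatic carbon.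

Going by the values given here, one measured step bears on this change: acetyl in place of hydrogen on the same aromatic ring, an 8.8-fold higher number from compound 1 to compound 2 (0.94 log units; beyond the scatter). That step is modest but beyond the scatter. Among the compounds with values here, it shows that a substituent on this ring can shift the number, but it concerns a different group, and no measured compound has hydroxy on this ring. The data therefore give no firm direction, and a step within the scatter is expected in this assay, with a wide margin either way. The expected step is a 1.4-fold lower number from compound 2 to compound 3 (0.15 log units; within the scatter). The estimate for compound 3 is 2.5 ug/mL, with an expected range of 0.7 ug/mL to 9 ug/mL.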

Compound 3, half-maximal inhibitory concentration: 6.8 ug/mL
Beside the measured number, compound 3's estimate is 2.7-fold (0.43 log units) below it; the measured number falls inside the stated range.
By their numbers in this assay, from the lowest: compound 1; then compounds 2 and 3 (each within the scatter of the next).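

In this assay, hydroxy in place of hydrogen on the aromatic carbon ortho to an acetyl group gives a 1.9-fold higher number from compound 2 to compound 3 (0.29 log units; within the scatter), so compound 2 and compound 3 cannot be told apart at this position. Going by these compounds alone, the earlier pair showed only that acetyl on this ring moves the number, with an 8.8-fold higher number from compound 1 to compound 2 (0.94 log units; beyond the scatter); the new step adds that hydroxy on a ring already bearing acetyl gives nothing beyond the scatter, and the full replacement of phenyl by 4-acetyl-3-hydroxyphenyl gives a 17-fold higher number from compound 1 to compound 3 (1.23 log units; beyond the scatter), so compound 1 remains clearly apart from both acetyl compounds. Nothing available here bears on why these numbers fall as they do.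

Still open, from the compounds shown here alone, is whether hydroxy on the phenyl end without the acetyl group would read close to compound 1 at 0.4 ug/mL or close to the acetyl compounds, and whether methoxy or an amine on the same carbon would behave as hydroxy does. Also open, going by these compounds, is whether a carboxylic acid or an amide in place of the acetyl group, or a longer chain between the two ether oxygens, would close the gap to compound 1.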